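A few compounds are considered here, and "the series" means these few. Any claim that something is new, unique, unknown or untested is made for them only; others in the source may bear on it.

The measured compounds:
compound 1 `C/C(=N\NC(=O)COc1cccc2ccccc12)c1ccccc1` — 20 ug/mL
compound 2 `O=C(COc1cccc2ccccc12)N/N=C/c1ccc([N+](=O)[O-])cc1` — 20 ug/mL
compound 3 `O=C(COc1cccc2ccccc12)N/N=C/c1c[nH]c2ccccc12` — 100 ug/mL

In an ADME assay on HEL cells (Homo sapiens) for cytotoxicity (a higher number here means that more compound is tolerated, a lower number that less compound is tolerated), compound 2 gives 20 ug/mL, level with compound 1 at the digits shown; together they are the lowest of the three numbers. Within the data shown here, compound 3, in this assay, gives 100 ug/mL, the one number that stands apart from compound 2, and the gap lies beyond the scatter.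

Compound 4 `Cc1ccc(/C=N/NC(=O)COc2cccc3ccccc23)cc1` has not yet been measured in this assay. It is reached from compound 2 by one change: methyl in place of nitro on an aromatic carbon. Among the measured compounds shown here, no step between measured compounds speaks to this change, so the expectation rests on the three numbers alone. Since compound 1 and compound 2 sit together while only compound 3 moves away, the step from compound 2 to compound 4 is expected to stay within the scatter, and is estimated at no change at the digits printed from compound 2 to compound 4 (within the scatter). For compound 4 the expected minimum cytotoxic concentration is 20 ug/mL, with a range from 10 ug/mL to 50 ug/mL.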

Compound 4, minimum cytotoxic concentration: 20 ug/mL
Compound 4: middle estimate and measured number agree at the digits printed, within the range that was stated.
By their numbers in this assay, from the lowest: compounds 1, 2 and 4 (each within the scatter of the next); then compound 3.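

In this assay, methyl in place of nitro on an aromatic carbon, para to a large group, gives no change at the digits printed from compound 2 to compound 4 (within the scatter). Among these compounds, this is the only step here that can be read at a single place, and it shows that at this position the number stays within the scatter when nitro, with its hydrogen-bond acceptors, gives way to methyl, which has none. Nothing measured here accounts for this flat step.

Only these two groups are shown at this position, so an amine, a carboxylic acid or a longer chain there could still behave differently. Among the compounds shown here, no step ties compound 3, at 100 ug/mL, to the other compounds, so what sets its number apart stays open.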